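Changing the Amide Group of Compound 3

The source may report more compounds than this note shows. Statements on the series, on what has been measured and on what is new or still open speak of the compounds shown alone.

In an ADME assay on L02 cells (Homo sapiens) for antiproliferative activity, read by MTT assay, with a stated time of 48 h (a lower number here means a stronger inhibitor, a higher number a weaker inhibitor), compound 1 `C#CCCOC(=O)c1ccc(C(CC)(CC)c2ccc(OCCC(O)(CC)CC)c(C)c2)n1CC` gives > 50000 nM, which is a limit of the assay. Compound 2 `CCn1c(C(=O)Nc2ccc(OC(F)(F)F)cc2)ccc1C(CC)(CC)c1ccc(OCCC(O)(CC)CC)c(C)c1` gives > 50000 nM, also a limit. Compound 3 `CCC(C)C(NC(=O)c1ccc(C(CC)(CC)c2ccc(OCCC(O)(CC)CC)c(C)c2)n1CC)C(=O)O`, at 9990 nM, is the only one of the three with an actual number. Compound 4 `CCn1c(C(=O)NC(CC(=O)O)C(=O)OC)ccc1C(CC)(CC)c1ccc(OCCC(O)(CC)CC)c(C)c1` differs from compound 3 on an amide-type nitrogen: a group of 9 heavy atoms (5 carbon, 4 oxygen; no ring) in place of a group of 8 heavy atoms (6 carbon, 2 oxygen; no ring), on an amide-type nitrogen. The closest guides are an at least 5.0-fold lower number from compound 2 to compound 3 (0.69 log units; beyond the scatter) and an at least 5.0-fold lower number from compound 1 to compound 3 (0.69 log units; beyond the scatter). As far as these compounds go, both start from a limit, so their full size is unknown, and neither tests a swap like this one. In this assay, within the data shown here, the expected change is a 1.5-fold higher number from compound 3 to compound 4 (0.18 log units; within the scatter), with no step expected beyond the scatter. For compound 4 the estimate is 15000 nM, with an expected range of 5000 nM to 50000 nM.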

Compound 4, half-maximal inhibitory concentration: 7590 nM
The estimate for compound 4 lay 2.0-fold (0.30 log units) above the measured number; the measured number falls inside the stated range.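

In this assay, placing a group of 9 heavy atoms on the amide-type nitrogen in place of 1-carboxy-2-methylbutyl gives a 1.3-fold lower number from compound 3 to compound 4 (0.12 log units; within the scatter), so two different open-chain groups here read alike. The other two comparisons are an at least 6.5-fold lower number from compound 2 to compound 4 (0.81 log units; beyond the scatter) and an at least 6.5-fold lower number from compound 1 to compound 4 (0.81 log units; beyond the scatter). Both start from a limit, so their full size stays unknown: the limit of > 50000 nM in this assay, at which 2 of the 4 values shown sit.

Compound 3 and compound 4 both carry a carboxylic acid, and whether that separates them from the limit compounds stays unresolved. As far as these compounds go, how a simple amine on this nitrogen would read also remains open.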